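The source may hold more compounds than are shown below. What is called first, only, known or untested is meant among the compounds shown, and "the series" means these compounds.

Measured so far in a functional assay (brain) for displacement of a labelled ligand, with Rattus norvegicus as the target; a higher number here means a weaker inhibitor, a lower number a stronger inhibitor: compound 1 `CCC[C@H](N)[C@H]1COC(c2ccccc2)(c2ccccc2)O1` gives 3450 nM; compound 2 `CCNC[C@H]1COC(c2ccccc2)(c2ccccc2)O1` gives 8400 nM; compound 3 `c1ccc(C2(c3ccccc3)OC[C@@H]([C@@H]3CCCN3)O2)cc1` gives 3300 nM.

Compound 3 holds the lowest of the three numbers, yet its gap to compound 1 lies within the scatter, so no order between those two can be read; only compound 2 stands beyond it. Compound 4 `c1ccc(C2(c3ccccc3)OC[C@H]([C@@H]3CCCN3)O2)cc1` keeps every atom and bond of compound 3 and differs in configuration alone: the two compounds have the same atoms and bonds and differ only in configuration as drawn: 1 of 2 stereo elements differ; a stereocentre at a saturated ring carbon is drawn R in compound 3 and S in compound 4. The single measured step, a 2.4-fold higher number from compound 1 to compound 2 (0.39 log units; beyond the scatter), exchanges one amine-bearing group for another and says nothing about configuration, so no shown step bears on this change. The direction is therefore open, and the estimated step is a 1.4-fold higher number from compound 3 to compound 4 (0.13 log units; within the scatter). For compound 4 in this assay the expected value is 4500 nM, within a wide range from 1500 nM to 15000 nM.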

Compound 4, inhibition constant: > 10000 nM
Compound 4 gave a limit, no number (the forecaster's own chance of this, stated with the estimate: 5%); middle value at least 2.2-fold (0.34 log units) away from the limit.
By their numbers in this assay, from the lowest: compounds 3 and 1 (each within the scatter of the next); then compound 2. At a limit, above all of these: compound 4.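

In this assay compound 4 gives > 10000 nM, a limit of the assay and not a number. With a stereocentre at a saturated ring carbon drawn R and then S, the data give an at least 3.0-fold higher number from compound 3 to compound 4 (0.48 log units; beyond the scatter). Configuration at this stereocentre is the only difference in this pair, and the step lies beyond the scatter. Against the 1-aminobutyl group, pyrrolidin-2-yl in this configuration gives an at least 2.8-fold higher number from compound 1 to compound 4 (0.46 log units; beyond the scatter), while the step against (ethylamino)methyl, an at least 1.1-fold higher number from compound 2 to compound 4 (0.07 log units; that floor lies within the scatter), cannot be read.

From the compounds shown here alone, the true size of the configuration step stays open. So does whether a piperidin-2-yl group in place of pyrrolidin-2-yl would keep this gap between the two configurations.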